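The source may hold more compounds than are shown below. What is called first, only, known or untested is meant among the compounds shown, and "the series" means these compounds.

Measured in an ADME assay on MT4 cells (Homo sapiens) for cytotoxicity, read by MTT assay, with a stated time of 5 days; on this read-out higher numbers stand for lower toxicity in this test and lower numbers for higher toxicity in this test:
compound 1, `CCN(c1ccnc(Nc2ccc(C#N)cc2)n1)c1c(F)cc(-c2ccc(C#N)cc2)cc1F`: 105000 nM
compound 2, `CCCCN(c1ccnc(Nc2ccc(C#N)cc2)n1)c1c(F)cc(-c2ccc(C#N)cc2)cc1F`: 211000 nM
compound 3, `N#Cc1ccc(Nc2nccc(N(c3c(F)cc(-c4ccc(C#N)cc4)cc3F)C3CCCC3)n2)cc1`: 232000 nM

Compound 3 gives the highest number of the three in this assay. One of its gaps is a 1.1-fold higher number from compound 2 to compound 3 (0.04 log units; within the scatter), so those two cannot be told apart, while the other is a 2.2-fold higher number from compound 1 to compound 3 (0.34 log units; beyond the scatter), a modest step. Between the two remaining compounds the step is a 2.0-fold higher number from compound 1 to compound 2 (0.30 log units; within the scatter).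

Compound 4 is `N#CCN(c1ccnc(Nc2ccc(C#N)cc2)n1)c1c(F)cc(-c2ccc(C#N)cc2)cc1F`. It differs from compound 3 at the place where the measured compounds also vary: cyanomethyl in place of cyclopentyl on a nitrogen on an aromatic ring. For the measured compounds named here, no measured pair carries a cyanomethyl group, so the steps that bear on this change are only indirect. The two steps that put cyclopentyl onto this nitrogen in place of a chain were a 2.2-fold higher number from compound 1 to compound 3 (0.34 log units; beyond the scatter) and a 1.1-fold higher number from compound 2 to compound 3 (0.04 log units; within the scatter), both small. Running the change the other way, from cyclopentyl to a short chain, the expectation is a small downward step at most, a 1.8-fold lower number from compound 3 to compound 4 (0.25 log units; within the scatter), which may well fall within the scatter. Compound 4 in this assay is estimated at 130000 nM, with a range from 60000 nM to 280000 nM.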

Compound 4, half-maximal cytotoxic concentration: 206000 nM
For compound 4 the middle estimate is 1.6-fold (0.20 log units) below the measured one; measured number inside the range.
By their numbers in this assay, from the lowest: compounds 1, 4, 2 and 3 (each within the scatter of the next, the first and the last beyond it).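

Cyanomethyl on this nitrogen reads the same in this assay as the saturated groups do, so a group with no ring, a triple bond and a hydrogen-bond acceptor fits at this place without a step that can be told from the scatter, both against cyclopentyl (a 1.1-fold lower number from compound 3 to compound 4 (0.05 log units; within the scatter)) and against the butyl chain (a 1.0-fold lower number from compound 2 to compound 4 (0.01 log units; within the scatter)). Against the ethyl chain the picture is the same (a 2.0-fold higher number from compound 1 to compound 4 (0.29 log units; within the scatter)), so compound 4 cannot be separated from any of the other three, even though compound 1 and compound 3 do stand apart (a 2.2-fold higher number from compound 1 to compound 3 (0.34 log units; beyond the scatter)). Nothing measured here bears on why the number holds across these groups.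

As far as these compounds go, whether a primary amine or a carboxylic acid carried on a chain at this nitrogen, or a plain hydrogen there, would stay in the same range remains open. The compounds shown also leave open whether this tolerance in this assay would persist with a longer chain ending in a nitrile, or with a change elsewhere on the shared core.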